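A few compounds are considered here, and "the series" means these few. Any claim that something is new, unique, unknown or untested is made for them only; others in the source may bear on it.

Measured compounds and their values:

Compound 1, `Nc1ccc(C(=O)NCCCOc2cccc(CN3CCCCC3)c2)cc1`, 6.82
Compound 2, `N#CN/C(=N\CCCNc1ccccc1[N+](=O)[O-])NCCCCOc1cccc(CN2CCCCC2)c1`, 7.85
Compound 3, `N#CN/C(=N\CCNC(=O)c1ccc(N=[N+]=[N-])cc1)NCCCOc1cccc(CN2CCCCC2)c1`, 7.9

The three compounds share a piperidinylmethyl-phenoxy chain and were tested in a functional assay on cardiac atrium for antagonist activity at histamine H2 receptor (Cavia porcellus); a higher number here means a more potent compound, by a factor of ten per unit of this negative logarithm, a lower number a less potent compound. Compound 1 gives 6.82, the lowest of the three, and its gap to compound 3 lies beyond the scatter. Compound 2 gives 7.85, and compound 3 gives 7.9; these two numbers sit within the scatter of each other, so no order between them can be read. Compound 3 therefore holds the highest number but is not clearly separated from compound 2.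

The next compound, compound 4 with the structure `N#CN/C(=N\CCCNC(=O)CCc1ccccc1)NCCCOc1cccc(CN2CCCCC2)c1`, keeps the cyanoguanidine-linked core of compound 3 and differs from it in a single place: ((phenethylcarbonyl)amino)methyl in place of ((4-azidophenyl)carbonyl)amino on a saturated chain carbon, two bonds along the chain from a double-bonded nitrogen. For the measured compounds named here, no measured pair shows the effect of this kind of exchange, so the expectation rests on the closeness of compound 2 and compound 3, both carrying the same core with different tails. A modest downward step is expected, a number 0.30 log units lower from compound 3 to compound 4 (within the scatter), within or near the scatter. Compound 4 is expected to give about 7.6, with a range from 7 to 8.2.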

Compound 4, negative logarithm of the antagonist equilibrium constant: 6.07
Beside the measured number, compound 4's estimate is 1.53 log units above it; the measured number lies below the stated range.
By their numbers in this assay, from the lowest: compound 4; then compound 1; then compounds 2 and 3 (each within the scatter of the next).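

In this assay the exchange of ((4-azidophenyl)carbonyl)amino for ((phenethylcarbonyl)amino)methyl brings a number 1.83 log units lower from compound 3 to compound 4 (beyond the scatter) and shows that the number is sensitive to what sits on this saturated chain carbon, two bonds along the chain from a double-bonded nitrogen. The two groups match in heavy atoms, hydrogen-bond donors and their one six-membered aromatic ring, so matching on those counts does not keep the number unchanged. Nothing measured here explains the drop.

The exchange alters the azide, the carbonyl's attachment to the ring and the chain at once, so the compounds shown do not say which of these matters. A (phenylcarbonyl)amino group, which has no azide, or a ((4-methoxyphenyl)carbonyl)amino group in the same place would begin to separate them.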